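Swapping Nitro for Hydroxy on a Measured Compound

The source may hold more compounds than are shown below. What is called first, only, known or untested is meant among the compounds shown, and "the series" means these compounds.

Among the compounds with values here, compound 1 `O=C(Nc1cccc([N+](=O)[O-])c1)c1cc(Cl)ccc1O` stands level with the only other compound measured so far. In an ADME assay for permeability, using PAMPA, with a stated time of 3 h (a higher number here means that the compound crosses the layer faster, a lower number that the compound crosses the layer more slowly), compound 1 gives 19.5 10^-6 cm/s and compound 2 `O=C(Nc1ccc(F)cc1)c1cc(Cl)ccc1O` gives 18.2 10^-6 cm/s and these two numbers lie within the scatter of each other. Compound 3 `O=C(Nc1cccc(O)c1)c1cc(Cl)ccc1O` keeps the core of compound 1 but carries hydroxy in place of nitro on an aromatic carbon, meta to a large group (hydroxy in place of nitro on an aromatic carbon). Within the data shown here, no two measured compounds differ in just one place, so the data offer no direct guide to this change and any forecast remains loose. A moderate fall in this assay is expected, with an estimated step of a 2.4-fold lower number from compound 1 to compound 3 (0.39 log units; beyond the scatter) that should lie slightly beyond the scatter. For compound 3 the expected value is 8 10^-6 cm/s with an estimated range from 3 10^-6 cm/s to 18 10^-6 cm/s for this measurement.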

Compound 3, apparent permeability: 15.9 10^-6 cm/s
Compound 3: the middle estimate sits 2.0-fold (0.30 log units) below what was measured; low and high end bracket the measured number.
By their numbers in this assay, from the lowest: compounds 3, 2 and 1 (each within the scatter of the next).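

Within the data shown here, this is the first pair of compounds that differ in one place, and in this assay hydroxy in place of nitro gives a 1.2-fold lower number from compound 1 to compound 3 (0.09 log units; within the scatter) on this aromatic carbon, a step that does not separate the two compounds. So, in this one pair, a hydrogen-bond donor can enter and the two extra heavy atoms of nitro can leave at this position without a change beyond the scatter. Nothing measured here explains why the two compounds read alike.

From the compounds shown here alone, a single pair sets no rule, so it remains open whether an amine or a carboxylic acid on the same carbon would also stay level with compound 1. Going by these compounds, it is also open whether hydroxy in place of nitro would give a similar step with the group placed elsewhere on that ring.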